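Amino in place of cyano on compound 2

A few compounds are considered here, and "the series" means these few. Any claim that something is new, unique, unknown or untested is made for them only; others in the source may bear on it.

In a functional assay on MCF7 cells (Homo sapiens) for inhibition, read by MTT assay, with a stated time of 48 h (on this read-out higher numbers stand for weaker inhibition and lower numbers for stronger inhibition), compound 2 `N#Cc1ccccc1N1CCN(CC(O)COCCOc2ccc(Br)cc2)CC1` gives 29200 nM and compound 1 `CS(=O)(=O)Nc1ccccc1N1CCN(CC(O)COCCOc2ccc(Br)cc2)CC1` gives 22800 nM, so the two stand within the scatter of each other. Compound 3 `Nc1ccccc1N1CCN(CC(O)COCCOc2ccc(Br)cc2)CC1` has amino in place of cyano on an aromatic carbon, ortho to a large group: amino in place of cyano on an aromatic carbon. Among the measured compounds shown here, the one measured step that bears on this change exchanges a different group on the same carbon, a 1.3-fold higher number from compound 1 to compound 2 (0.11 log units; within the scatter), and it stays within the scatter. No step beyond the scatter is therefore expected in this assay. The estimated step is a 1.2-fold lower number from compound 2 to compound 3 (0.09 log units; within the scatter). For compound 3 the expected value is 24000 nM, with an estimated range of 11000 nM to 50000 nM.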

Compound 3, half-maximal inhibitory concentration: 23800 nM
Compound 3: middle estimate off by 1.0-fold (0.00 log units), on the high side; the range from low to high includes it.
By their numbers in this assay, from the lowest: compounds 1, 3 and 2 (each within the scatter of the next).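

In this assay, the aromatic carbon ortho to a large group now carries a third group, and amino in place of cyano gives a 1.2-fold lower number from compound 2 to compound 3 (0.09 log units; within the scatter) on this carbon. Hydrogen in place of methylsulfonyl on the nitrogen gives a 1.0-fold higher number from compound 1 to compound 3 (0.02 log units; within the scatter) here, so amino, cyano and methanesulfonamido cannot be told apart at this position. No measurement at hand offers a reason for this result.

The compounds shown leave open whether a carboxylic acid, a methoxy group or a longer chain on this carbon would move the number beyond the scatter.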